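The source may hold more compounds than are shown below. What is called first, only, known or untested is meant among the compounds shown, and "the series" means these compounds.

Measured so far in a physicochemical assay for permeability, using PAMPA, at pH 7.4; a higher number here means that the compound crosses the layer faster, a lower number that the compound crosses the layer more slowly:
compound 1 `CC(C)(C)NC(=O)NCCS(=O)(=O)NC(=O)c1ccc(Nc2nc(NC3(c4ccc(Cl)cc4)CC3)nc(OCC(F)(F)F)n2)cc1` gives 49 nm/s
compound 2 `O=C(NS(=O)(=O)CCNCc1ccccc1)c1ccc(Nc2nc(NC3(c4ccc(Cl)cc4)CC3)nc(OCC(F)(F)F)n2)cc1` gives 49 nm/s

Among the compounds with values here, compound 1 stands level with compound 2; the one measured step, no change at the digits printed from compound 1 to compound 2 (within the scatter), lies within the scatter. Compound 3 `CS(=O)(=O)NC(=O)c1ccc(Nc2nc(NC3(c4ccc(Cl)cc4)CC3)nc(OCC(F)(F)F)n2)cc1` differs from compound 1 by hydrogen in place of (((tert-butyl)carbamoyl)amino)methyl on a saturated chain carbon bound to a sulfonyl sulfur. Within the data shown here, no measured step removes this group outright; the step from compound 1 to compound 2 only exchanges its end and shows no movement. The expectation for compound 3 is therefore a small rise at most, a 1.4-fold higher number from compound 1 to compound 3 (0.15 log units; within the scatter), likely within the scatter. Compound 3 is estimated at 70 nm/s, with a range of 30 nm/s to 160 nm/s.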

Compound 3, apparent permeability: 11 nm/s
Compound 3: the middle estimate sits 6.4-fold (0.80 log units) above what was measured; the measured number lies below the stated range.
By their numbers in this assay, from the lowest: compound 3; then compounds 1 and 2 (each within the scatter of the next).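

Removing the chain from the saturated chain carbon bound to a sulfonyl sulfur moves the number in this assay, giving a 4.5-fold lower number from compound 1 to compound 3 (0.65 log units; beyond the scatter) and a 4.5-fold lower number from compound 2 to compound 3 (0.65 log units; beyond the scatter). This position therefore matters for this read-out, although the end of the chain could be exchanged between compound 1 and compound 2 with no change at the digits printed. No measurement shown accounts for the drop.

As far as these compounds go, whether a plain ethyl or propyl in place of the methyl of compound 3 restores the number remains open. So does the outcome for a chain ending in a carboxylic acid.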